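The source may report more compounds than this note shows. Statements on the series, on what has been measured and on what is new or still open speak of the compounds shown alone.

In an ADME assay on HEK293 cells for agonist activity at metabotropic glutamate receptor 5 (Rattus norvegicus), read by fluorescence and calcium flux (on this read-out higher numbers stand for larger maximal responses and lower numbers for smaller maximal responses), compound 1 `C[C@@H](NC(=O)c1ccc(C#Cc2cccc(F)c2)nc1)C(C)(C)O` gives 26.6%. Compound 2 `C[C@H](NC(=O)c1ccc(C#Cc2cccc(F)c2)cn1)C(C)(C)C` gives 20% in this assay. Of the two numbers this is the lower, yet the gap to compound 1 sits within the usual scatter, so no real difference can be read between them. Compound 3 `CC(C)(C)CNC(=O)c1ccc(C#Cc2cccc(F)c2)cn1` has not yet been measured. It differs from compound 2 in one place: hydrogen in place of methyl on a saturated chain carbon bound to an amide-type nitrogen and a saturated chain carbon. For the measured compounds named here, no measured pair shows this change. The step from compound 2 to compound 3 is expected to be small, with no direction beyond the scatter. Compound 3 is therefore estimated at 22% in this assay, most likely between 8% and 40%. The expected step is a number 2 percentage points higher from compound 2 to compound 3 (within the scatter).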

Compound 3, largest response reached (reported as efficacy), in percent of the reference or control that the assay uses: 9.5%
Estimate against measurement, compound 3: 12.5 percentage points above, within the range that was stated.
By their numbers in this assay, from the lowest: compound 3; then compounds 2 and 1 (each within the scatter of the next).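

In this assay, for the compounds shown here, the first comparison that differs in one place shows that this single methyl counts: with hydrogen in its place on the saturated chain carbon, turning 1,2,2-trimethylpropyl into neopentyl, the maximal response falls by a modest step (a number 10.5 percentage points lower from compound 2 to compound 3 (beyond the scatter)). So this carbon is not a silent position on the chain. No supporting measurement explains the step. As far as these compounds go, whether an ethyl or a hydroxymethyl group on this same carbon would give a larger or smaller response stays open, as does whether the same step holds on the core of compound 1.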